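Chain-end group swap on compound 1 in a whole-animal read-out

The source may report more compounds than this note shows. Statements on the series, on what has been measured and on what is new or still open speak of the compounds shown alone.

Measured compounds:
compound 1 `C/N=C(/NC#N)NCCCCCn1nc(-c2ccccc2)ccc1=O` 47.6%
compound 2 `C/N=C(/NC#N)NCCCCCn1nc(-c2ccccc2)c(C)cc1=O` 28.5%
compound 3 `CC/N=C(/NC#N)NCCCCCCn1nc(-c2ccccc2)ccc1=O` 29.1%

In a functional assay on the whole organism with Rattus norvegicus as the target, at a dose of 100 mg/kg (on this read-out lower numbers stand for less inhibition and higher numbers for more inhibition at the one dose given (going by the name of the read-out)), compound 1 gives the highest of the three numbers. Compound 2 sits a number 19.1 percentage points lower from compound 1 to compound 2 (beyond the scatter) through a methyl in place of hydrogen on an aromatic carbon, and compound 3 sits a number 18.5 percentage points lower from compound 1 to compound 3 (beyond the scatter) through a change of the group on the saturated chain carbon.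

Compound 4 `CC/N=C(\S)NCCCCn1nc(-c2ccccc2)ccc1=O` is not yet measured. It differs from compound 1 in one place: a group of 6 heavy atoms (3 carbon, 2 nitrogen, 1 sulfur; no ring) in place of a group of 8 heavy atoms (4 carbon, 4 nitrogen; no ring), on a saturated chain carbon, four bonds along the chain from an aromatic nitrogen

Among the compounds with values here, of the measured steps, only the one from compound 1 to compound 3 touches the same chain-end region, and that change cost a modest amount in this assay. The change in compound 4 is larger in kind, replacing the whole group and shortening the chain, so a step of similar or somewhat greater size, downward, is expected; the step from compound 1 to compound 2 does not bear on it.

Compound 4 is estimated at 28%, between 8% and 48%, which would be a number 19.6 percentage points lower from compound 1 to compound 4 (beyond the scatter).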

Compound 4, a percentage reported as inhibition, in the whole organism at one dose (the size of the read-out at that dose, not a potency): 67.7%
Beside the measured number, compound 4's estimate is 39.7 percentage points below it; measured number above the stated range.
By their numbers in this assay, from the lowest: compounds 2 and 3 (each within the scatter of the next); then compound 1; then compound 4.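

In this assay, this position proves able to move the read-out upward as well as downward: the change gives a number 20.1 percentage points higher from compound 1 to compound 4 (beyond the scatter), whereas the earlier change at the chain end gave a number 18.5 percentage points lower from compound 1 to compound 3 (beyond the scatter). The group that enters, with 6 heavy atoms including 1 sulfur, has no triple bond and thus no nitrile, so the nitrile is not required for a number above that of compound 1 at this dose. Nothing measured here accounts for the rise.

The compounds shown leave open whether the rise belongs to the sulfur-bearing end or to the shorter chain, as the two arrive together in this one step. They also leave open how an oxygen in place of the sulfur, or a simple amine at the chain end, would read in this assay.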